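This account rests on a few compounds, and the source may have more. Where it says the series, first, only, none or still open, it means among the compounds named here.

Measured compounds in an ADME assay on the whole organism (plasma) for metabolic stability, with Rattus norvegicus as the target; on this read-out lower numbers stand for a shorter-lived compound and higher numbers for a longer-lived compound:
compound 1, `CCCOC(=O)CCCC=C(c1cc(Br)c(OC)c(C(=O)OC)c1)c1cc(Br)c(OC)c(C(=O)OC)c1`, gives 0.0567 h
compound 2, `CCCOC(=O)CCCC=C(c1cc(C)c(OC)c(C(=O)OC)c1)c1cc(C)c(OC)c(C(=O)OC)c1`, gives 0.0867 h
compound 3, `COC(=O)c1cc(C(=CCCCC(=O)OC(C)C)c2cc(Br)c(OC)c(C(=O)OC)c2)cc(Br)c1OC`, gives 0.095 h

Compound 1 and compound 3 share one core and differ in a single spot: isopropyl in place of propyl on an oxygen next to a carbonyl group. In this assay this gives a 1.7-fold higher number from compound 1 to compound 3 (0.22 log units; within the scatter), so the change reads as flat on this read-out.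

Compound 2 carries the other core of the series; the difference between the two cores is not broken down here. The values of compound 2 and compound 3 lie within the scatter of each other, as do those of compound 2 and compound 1.

Compound 4, `COC(=O)c1cc(C(=CCCCC(=O)OC(C)C)c2cc(C)c(OC)c(C(=O)OC)c2)cc(C)c1OC`, is compound 2 with the same change applied: isopropyl in place of propyl on an oxygen next to a carbonyl group. The place is described in the same words for both pairs, so it is the same change, carried over from the other core. For the measured compounds named here, the step is expected to be a 1.5-fold higher number from compound 2 to compound 4 (0.18 log units; within the scatter), matched to what compound 1 to compound 3 showed in a 1.7-fold higher number from compound 1 to compound 3 (0.22 log units; within the scatter), and only one earlier instance supports it. On that basis compound 4 is estimated at 0.13 h in this assay, with a range from 0.07 h to 0.25 h.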

Compound 4, half-life: 0.0283 h
The estimate for compound 4 lay 4.6-fold (0.66 log units) above the measured number; measured number outside the range, below it.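

In this assay, isopropyl in place of propyl on an oxygen next to a carbonyl group gives a 3.1-fold lower number from compound 2 to compound 4 (0.49 log units; beyond the scatter), so on the core of compound 2 the change produces a shorter-lived compound. The step therefore does not carry over unchanged from one core to the other: the same change on two cores in this assay, a 1.7-fold higher number (0.22 log units; within the scatter) from compound 1 to compound 3 and a 3.1-fold lower number (0.49 log units; beyond the scatter) from compound 2 to compound 4, 5.1-fold (0.71 log units) apart, beyond the scatter of two such steps. For the compounds shown here, this rests on a single pair per core, so it shows only that the step differs between these two cores; it gives no reason for the difference and no rule for any further core.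

Still open, going by these compounds, is how an ethyl or tert-butyl group on the same oxygen would read on both cores, and whether the two cores would again part. Also open, on these data alone, is whether a carboxylic acid or an amide in place of the ester carrying the propyl or isopropyl group would show the same dependence on the core.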